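Shifting the methoxy group on the aryl of compound 3

This account rests on a few compounds, and the source may have more. Where it says the series, first, only, none or still open, it means among the compounds named here.

Three analogues sharing one core differ only in the aryl group on the five-membered ring. Compound 1 `COc1ccc(-c2cc(COC(Cc3cn(C4CCN(Cc5ccc([N+](=O)[O-])cc5)CC4)nn3)c3ccc(Br)cc3)on2)cc1` gives in a functional assay on MCF7 cells (Homo sapiens) for cytotoxicity, with a stated time of 48 h (a lower number here means a stronger inhibitor, a higher number a weaker inhibitor), a value of 4000 nM. Compound 2 `COc1cccc(-c2cc(COC(Cc3cn(C4CCN(Cc5ccc([N+](=O)[O-])cc5)CC4)nn3)c3ccc(Br)cc3)on2)c1` gives 7000 nM. Compound 3 `N#Cc1cccc(-c2cc(COC(Cc3cn(C4CCN(Cc5ccc([N+](=O)[O-])cc5)CC4)nn3)c3ccc(Br)cc3)on2)c1` gives 2000 nM, the lowest of the three numbers; the step of a 2.0-fold lower number from compound 1 to compound 3 (0.30 log units; within the scatter) stays within the scatter, while a 3.5-fold lower number from compound 2 to compound 3 (0.54 log units; beyond the scatter) lies beyond it. Compound 4 `COc1ccccc1-c1cc(COC(Cc2cn(C3CCN(Cc4ccc([N+](=O)[O-])cc4)CC3)nn2)c2ccc(Br)cc2)on1` carries 2-methoxyphenyl in place of 3-cyanophenyl on an aromatic carbon. Within the data shown here, two steps bear on it: a 3.5-fold lower number from compound 2 to compound 3 (0.54 log units; beyond the scatter) shows that replacing methoxy by cyano lowered the number, and a 1.8-fold higher number from compound 1 to compound 2 (0.24 log units; within the scatter) shows that moving the methoxy group changed little. Reversing the cyano for methoxy exchange is therefore expected to raise the number again, by about a 2.5-fold higher number from compound 3 to compound 4 (0.40 log units; beyond the scatter). Compound 4 is accordingly estimated at 5000 nM, between 2000 nM and 14000 nM.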

Compound 4, half-maximal inhibitory concentration: 3000 nM
Beside the measured number, compound 4's estimate is 1.7-fold (0.22 log units) above it; low and high end bracket the measured number.
By their numbers in this assay, from the lowest: compounds 3, 4, 1 and 2 (each within the scatter of the next, the first and the last beyond it).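

In this assay, moving the methoxy group on the aryl makes a difference beyond the scatter in one comparison at this carbon (a 2.3-fold lower number from compound 2 to compound 4 (0.37 log units; beyond the scatter)). The 2-methoxyphenyl group is not separated from the 4-methoxyphenyl group (a 1.3-fold lower number from compound 1 to compound 4 (0.12 log units; within the scatter)) or from the 3-cyanophenyl group (a 1.5-fold higher number from compound 3 to compound 4 (0.18 log units; within the scatter)), so only the 3-methoxyphenyl group stands apart from it. No supporting measurement explains this dependence on position. The compounds shown leave open how a 2-cyanophenyl or 4-cyanophenyl group would compare, and whether an aminophenyl or carboxyphenyl group would fit this series.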